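The source may report more compounds than this note shows. Statements on the series, on what has been measured and on what is new or still open speak of the compounds shown alone.

Compound 1 `CC(C)(C)c1ccc(CN2CCN(S(=O)(=O)Nc3ccc(SCCc4ccccc4)cc3C(=O)O)CC2)cc1` gives 32800 nM in a functional assay on HL-60 cells (Homo sapiens) for inhibition, read by WST assay, with a stated time of 4 days; on this read-out higher numbers stand for weaker inhibition and lower numbers for stronger inhibition
Compound 2 `CCC(=O)N1CCN(c2c3ccc(-c4cccc(F)c4)cc3nn2Cc2ccccc2)CC1` gives 28900 nM in this assay

Of the compounds shown here, two with clearly different structures have been measured so far. Compound 2 at 28900 nM and compound 1 at 32800 nM lie within the usual scatter of each other, so the numbers do not rank one ahead of the other. Compound 3 `C=CC(=O)N1CCN(c2c3ccc(-c4cccc(F)c4)cc3nn2Cc2ccccc2)CC1` departs from compound 2 in a single place. The change vinyl in place of ethyl on a carbonyl carbon puts vinyl in place of ethyl on a carbonyl carbon, turning 4-propanoylpiperazin-1-yl into 4-(vinylcarbonyl)piperazin-1-yl while the rest of the molecule stays the same. For the measured compounds named here, no measured pair shows what this exchange does in this assay and the expectation therefore rests on the structural change alone, with wide uncertainty. A moderate move toward stronger inhibition, beyond the scatter, is expected, and the estimated 4.8-fold lower number from compound 2 to compound 3 (0.68 log units; beyond the scatter) is offered on that basis. Compound 3 is expected at about 6000 nM (estimated range 1000 nM to 30000 nM).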

Compound 3, half-maximal inhibitory concentration: 10700 nM
For compound 3 the middle estimate is 1.8-fold (0.25 log units) below the measured one, and the stated range covers the measured number.
By their numbers in this assay, from the lowest: compound 3; then compounds 2 and 1 (each within the scatter of the next).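

In this assay, for the compounds shown here, vinyl in place of ethyl on a carbonyl carbon gives a 2.7-fold lower number from compound 2 to compound 3 (0.43 log units; beyond the scatter), the first step that can be read from a pair differing in one place. It shows that 4-propanoylpiperazin-1-yl is a place where the number responds to a modest structural edit: the heavy-atom count stays the same, and the only difference counted is one double bond outside aromatic rings. The data at hand offer no explanation for why 4-(vinylcarbonyl)piperazin-1-yl gives the lower number.

The compounds shown place only ethyl and vinyl on this carbonyl carbon, so they do not establish a trend, and it remains open whether a longer chain, a terminal dimethylamino group on the vinyl or a chloromethyl group there would lower the number further, leave it unchanged or raise it. This single pair also leaves open whether the same exchange would give a step of similar size on a different core.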